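This account rests on a few compounds, and the source may have more. Where it says the series, first, only, none or still open, it means among the compounds named here.

Three measured compounds share one core and differ only in the chain that carries the amine. Compound 1 `COc1cccc(-c2c(C)n(Cc3c(F)cccc3F)c(=O)n(C[C@@H](N)CC(C)C)c2=O)c1F` gives 39 nM in an assay on HEK293 cells for binding affinity to Gonadotropin-releasing hormone receptor (Homo sapiens), read by radioligand binding; on this read-out lower numbers stand for stronger inhibition and higher numbers for weaker inhibition. Compound 2 `COc1cccc(-c2c(C)n(Cc3c(F)cccc3F)c(=O)n(C[C@@H](N)C(C)C)c2=O)c1F` gives 973 nM, the highest of the three numbers, and compound 3 `COc1cccc(-c2c(C)n(Cc3c(F)cccc3F)c(=O)n(C[C@H](N)C(C)C)c2=O)c1F` gives 51 nM. The largest steps are a 25-fold higher number from compound 1 to compound 2 (1.40 log units; beyond the scatter) and a 19-fold lower number from compound 2 to compound 3 (1.28 log units; beyond the scatter), whereas a 1.3-fold higher number from compound 1 to compound 3 (0.12 log units; within the scatter) stays small. Because (the fact that compounds 2 and 3 differ only in the configuration as drawn), the drawn configuration alone accounts for most of the spread seen so far.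

Compound 4 `COc1cccc(-c2c(C)n(Cc3c(F)cccc3F)c(=O)n(C[C@H](N)C3CCCCC3)c2=O)c1F` has not been measured. Compared with compound 2 it carries amino(cyclohexyl)methyl in place of 1-amino-2-methylpropyl on a saturated chain carbon bound to an aromatic nitrogen, and its stereocentre is drawn as in compound 3 rather than as in compound 2. The step from compound 2 to compound 3 and the small step from compound 1 to compound 3 suggest that a configuration drawn this way gives a low number whether the branch is small or larger. A large step downward is therefore expected, a 24-fold lower number from compound 2 to compound 4 (1.39 log units; beyond the scatter), and compound 4 is estimated at 40 nM in this assay, within 10 nM to 200 nM.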

Compound 4, inhibition constant: 6.5 nM
Compound 4: the middle estimate sits 6.2-fold (0.79 log units) above what was measured; measured number below the stated range.
By their numbers in this assay, from the lowest: compound 4; then compounds 1 and 3 (each within the scatter of the next); then compound 2.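

On the saturated chain carbon bound to an amine nitrogen and a saturated chain carbon, the size and shape of the branch now matter: with the stereocentre drawn as in compound 3, cyclohexyl in place of isopropyl gives a 7.8-fold lower number from compound 3 to compound 4 (0.89 log units; beyond the scatter). The cyclohexyl branch also goes beyond the open-chain 1-amino-3-methylbutyl group, with a 6.0-fold lower number from compound 1 to compound 4 (0.78 log units; beyond the scatter), so the earlier impression that the branch made little difference holds only for the two open-chain groups. The largest step, a 150-fold lower number from compound 2 to compound 4 (2.18 log units; beyond the scatter), combines the branch change with a change of drawn configuration, and configuration alone can produce a large step: the fact that compounds 2 and 3 differ only in the configuration as drawn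

As far as these compounds go, whether a cyclopentyl or a phenyl branch would give a similarly low number remains open. So does whether cyclohexyl would keep its advantage with the stereocentre drawn as in compound 2.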